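From dimethylamino to pyrrolidin-1-yl on a carbonyl carbon

A few compounds are considered here, and "the series" means these few. Any claim that something is new, unique, unknown or untested is made for them only; others in the source may bear on it.

Measured so far in an ADME assay on MDCKII-LE cells (Canis lupus familiaris) for permeability; on this read-out higher numbers stand for higher permeability and lower numbers for lower permeability:
- compound 1 `Cc1cnc(NC(=O)c2cc(Oc3cnc(C(=O)N(C)C)cn3)c3cc(C)oc3c2)cn1` gives 22.3 10^-6 cm/s
- compound 2 `Cc1cnc(NC(=O)c2cc(Oc3ccc(C(=O)N(C)C)cc3)c3cc(C)oc3c2)cn1` gives 5.9 10^-6 cm/s
- compound 3 `Cc1cnc(NC(=O)c2cc(Oc3ncc(C(=O)N(C)C)cn3)c3cc(C)oc3c2)cn1` gives 34.7 10^-6 cm/s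

The numbers of compound 1 and compound 3 lie within the usual scatter of each other, so they cannot be told apart. Compound 2 stands clearly lower than compound 1. Compound 4 `Cc1cnc(NC(=O)c2cc(Oc3cnc(C(=O)N4CCCC4)cn3)c3cc(C)oc3c2)cn1` keeps the core of compound 1 and has pyrrolidin-1-yl in place of dimethylamino on a carbonyl carbon. Among the measured compounds shown here, no measured pair shows this change, so the data offer no direct guide, and no shift beyond the scatter is expected in this assay in either direction. The expected size is a 1.1-fold lower number from compound 1 to compound 4 (0.03 log units; within the scatter), which stays within the scatter. Compound 4 is estimated at 21 10^-6 cm/s with a range from 11 10^-6 cm/s to 38 10^-6 cm/s.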

Compound 4, apparent permeability: 15.8 10^-6 cm/s
Beside the measured number, compound 4's estimate is 1.3-fold (0.12 log units) above it; the measured number falls inside the stated range.
By their numbers in this assay, from the lowest: compound 2; then compounds 4, 1 and 3 (each within the scatter of the next, the first and the last beyond it).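

In this assay, among the compounds shown here, pyrrolidin-1-yl in place of dimethylamino on a carbonyl carbon gives a 1.4-fold lower number from compound 1 to compound 4 (0.15 log units; within the scatter) and so offers the first direct reading at this place: a group with a ring and more heavy atoms leaves the read-out indistinguishable from that of compound 1. No available measurement bears on this result. Open remains how morpholin-4-yl, or a carboxylic acid in place of the whole amide, would read here, and whether pyrrolidin-1-yl would behave the same way on the cores of compound 2 and compound 3.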